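Sulfonyl and carbamoyl substituents on a shared quinolone core

This account rests on a few compounds, and the source may have more. Where it says the series, first, only, none or still open, it means among the compounds named here.

Two measured compounds share the core. Compound 1 `O=c1c(S(=O)(=O)c2ccccc2)c[nH]c2cc(F)ccc12` carries a phenylsulfonyl group and a fluoro group; in an assay for binding affinity to C-type lectin domain family 4 member M (Homo sapiens), read by reporter gene assay and NMR (a higher number here means weaker binding, a lower number tighter binding), compound 1 gives 1900000 nM. Compound 2 `CN(C)C(=O)c1c[nH]c2ccc(F)cc2c1=O` carries a dimethylcarbamoyl group and a fluoro group; in this assay compound 2 gives 2900000 nM. The two numbers lie within the scatter of each other, so compound 1 stands level with compound 2 and neither can be placed ahead.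

Compound 3 `CN(C)C(=O)c1ccc2c(=O)c(S(=O)(=O)c3ccccc3)c[nH]c2c1` is not yet measured. Compared with compound 1 the change is dimethylcarbamoyl in place of fluoro on an aromatic carbon, on the ring that carries no substituent in compound 2. Among the measured compounds shown here, no step between measured compounds covers this change, so nothing here tells its size or direction. The step from compound 1 to compound 3 in this assay is expected to be a 1.1-fold higher number from compound 1 to compound 3 (0.02 log units; within the scatter), that is, none beyond the scatter. For compound 3 in this assay the estimate is 2000000 nM, with a range from 600000 nM to 7000000 nM.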

Compound 3, dissociation constant: 300000 nM
Compound 3: middle estimate off by 6.7-fold (0.82 log units), on the high side; measured number outside the range, below it.
By their numbers in this assay, from the lowest: compound 3; then compounds 1 and 2 (each within the scatter of the next).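

With the phenylsulfonyl group held constant, dimethylcarbamoyl in place of fluoro on this aromatic carbon gives a 6.3-fold lower number from compound 1 to compound 3 (0.80 log units; beyond the scatter) in this assay. Among the compounds shown here, this is the first step that can be read at a single position, and it shows that this carbon accepts the dimethylcarbamoyl group with tighter binding, not merely without loss. Nothing measured here bears on why binding tightens.

For the compounds shown here, the single step does not separate the loss of fluoro from the arrival of dimethylcarbamoyl, so a plain hydrogen at this carbon would be needed to tell the two apart. It also leaves open whether the dimethyl groups matter, which an unsubstituted carboxamide, a carboxylic acid or an amine at the same carbon could test.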